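Ester chain lengthening on a cinnamate prodrug series

This account rests on a few compounds, and the source may have more. Where it says the series, first, only, none or still open, it means among the compounds named here.

Three compounds share one core and differ only at the cinnamate end. In an ADME assay on stomach for pharmacokinetics, in simulated gastric fluid (a higher number here means that the compound lasts longer, a lower number that the compound disappears faster), compound 1 `CCOc1cc(NC(=O)C2(NC(=O)c3ccc4c(C5CCCC5)c(-c5ncc(Cl)cn5)n(C)c4c3)CCC2)ccc1/C=C/C(=O)N[C@@H](CCC(=O)O)C(N)=O` gives 0.533 h, compound 2 `CCOc1cc(NC(=O)C2(NC(=O)c3ccc4c(C5CCCC5)c(-c5ncc(Cl)cn5)n(C)c4c3)CCC2)ccc1/C=C/C(=O)OCOP(=O)(O)O` gives 1.3 h, and compound 3 `CCOC(=O)/C=C/c1ccc(NC(=O)C2(NC(=O)c3ccc4c(C5CCCC5)c(-c5ncc(Cl)cn5)n(C)c4c3)CCC2)cc1OCC` gives 0.333 h. Compound 3 sits at the low end: a 1.6-fold lower number from compound 1 to compound 3 (0.20 log units; within the scatter), while a 3.9-fold lower number from compound 2 to compound 3 (0.59 log units; beyond the scatter). Compound 4 `CCCOC(=O)/C=C/c1ccc(NC(=O)C2(NC(=O)c3ccc4c(C5CCCC5)c(-c5ncc(Cl)cn5)n(C)c4c3)CCC2)cc1OCC` carries methyl in place of hydrogen on a saturated chain carbon, two bonds along the chain from an oxygen next to a carbonyl group. Among the measured compounds shown here, no measured step changes this chain; the nearest comparison is the swap on the carbonyl carbon, where a 1.6-fold lower number from compound 1 to compound 3 (0.20 log units; within the scatter). For the measured compounds named here, with that small step as the only guide, no change beyond the scatter is expected in this assay, so the expected step is a 1.1-fold higher number from compound 3 to compound 4 (0.02 log units; within the scatter). Compound 4 is therefore estimated at 0.35 h, within a range from 0.17 h to 0.7 h.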

Compound 4, half-life: 2.23 h
For compound 4 the middle estimate is 6.4-fold (0.80 log units) below the measured one; the measured number lies above the stated range.
By their numbers in this assay, from the lowest: compounds 3 and 1 (each within the scatter of the next); then compounds 2 and 4 (each within the scatter of the next).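

Ethoxy to propoxy on this ester is not a small change in this assay: one added methyl gives a 6.7-fold higher number from compound 3 to compound 4 (0.83 log units; beyond the scatter), so this chain end alone can move the number beyond the scatter. Propoxy in place of the (1-carbamoyl-3-carboxypropyl)amino group gives a 4.2-fold higher number from compound 1 to compound 4 (0.62 log units; beyond the scatter), whereas the swap from the phosphorus-bearing group stays small, with a 1.7-fold higher number from compound 2 to compound 4 (0.23 log units; within the scatter). Nothing available explains why one methyl matters so much.

From the compounds shown here alone, whether a butyl ester or a longer chain would raise, hold or lower this half-life remains open, as does the effect of an amine at the chain end.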